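One Ring Swap on Two Cores: Expecting Compound 4

The compounds below may be only part of what the source reports. "The series", "measured", "known", "first", "only" and "open" are said of these compounds alone.

Measured so far in a functional assay on cells (Cancer cell lines, Homo sapiens) for cytotoxicity, read by sulforhodamine B assay, with a stated time of 48 h; on this read-out higher numbers stand for weaker inhibition of growth and lower numbers for stronger inhibition of growth:
- compound 1, `Oc1ccc(O)c(-c2cc(-c3ccc(Cl)cc3)nn2-c2ccccc2)c1`, gives 6850 nM
- compound 2, `CC(=O)NS(=O)(=O)c1ccc(-n2nc(-c3ccccc3)cc2-c2cc(O)ccc2O)cc1`, gives 93900 nM
- compound 3, `O=C1C=CC(=O)C(c2cc(-c3ccc(Cl)cc3)nn2-c2ccccc2)=C1`, gives 53500 nM

Compound 1 and compound 3 differ in one place: a group of 8 heavy atoms (6 carbon, 2 oxygen; one six-membered non-aromatic ring of carbon only) in place of a group of 8 heavy atoms (6 carbon, 2 oxygen; one six-membered aromatic ring of carbon only), on an aromatic carbon. The step is a 7.8-fold higher number from compound 1 to compound 3 (0.89 log units; beyond the scatter).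

Compound 2 carries a different core; how it differs from compound 1 is not broken down here. Among the three, compound 2 shows the highest number, its value lying within the scatter of compound 3 and beyond the scatter of compound 1.

Compound 4 `CC(=O)NS(=O)(=O)c1ccc(-n2nc(-c3ccccc3)cc2C2=CC(=O)C=CC2=O)cc1` has not yet been tested in this assay. It stands to compound 2 as compound 3 stands to compound 1: a group of 8 heavy atoms (6 carbon, 2 oxygen; one six-membered non-aromatic ring of carbon only) in place of a group of 8 heavy atoms (6 carbon, 2 oxygen; one six-membered aromatic ring of carbon only), on an aromatic carbon. Around the place the surroundings are not identical, since here the changed carbon sits next to the ring atom that bears a large group and two ring bonds from the ring atom that bears a phenyl group, so this is the same kind of change rather than the same change.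

Within the data shown here, compound 4 is expected to show a step of a 3.7-fold higher number from compound 2 to compound 4 (0.57 log units; beyond the scatter) in this assay, because a 7.8-fold higher number from compound 1 to compound 3 (0.89 log units; beyond the scatter) is the only precedent. Compound 4 is estimated at 350000 nM, within 120000 nM to 1000000 nM, with a real chance that this assay reports only a limit.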

Compound 4, concentration for 50% growth inhibition: 100000 nM
The estimate for compound 4 lay 3.5-fold (0.54 log units) above the measured number; measured number outside the range, below it.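

On the core of compound 2, putting the non-aromatic ring in place of the 2,5-dihydroxyphenyl group in this assay gave a 1.1-fold higher number from compound 2 to compound 4 (0.03 log units; within the scatter). The step seen on the core of compound 1 thus did not carry over in size, and the two steps stand clearly apart: the same change on two cores in this assay, a 7.8-fold higher number (0.89 log units; beyond the scatter) from compound 1 to compound 3 and a 1.1-fold higher number (0.03 log units; within the scatter) from compound 2 to compound 4, 7.3-fold (0.87 log units) apart, beyond the scatter of two such steps. This shows that, in these two pairs, the same change does not give a step of the same size on both cores, but it does not show which difference between the cores goes with the gap, since they differ in more than one place.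

The compounds shown leave open whether the chlorine atom or the acetyl sulfonamide group goes with the gap, as no core here carries one without the other. They also leave open how the step would read on a core with a carboxylic acid or an unsubstituted sulfonamide in place of the acetyl sulfonamide.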